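A ring swap on the amine nitrogen of compound 1

The source may hold more compounds than are shown below. What is called first, only, known or untested is meant among the compounds shown, and "the series" means these compounds.

Measured so far:
- Compound 1 `CCOC(=O)C1=C(C)NC(=S)NC1c1cn(C(=O)CNc2ccc([N+](=O)[O-])cc2C)c2ccccc12` gives 3.34 as its value
- Compound 2 `CCOC(=O)C1=C(C)NC(=O)NC1c1cn(C(=O)CNc2ccccc2N)c2ccccc12` gives 0.74 as its value

In a physicochemical assay for lipophilicity (on this read-out lower numbers stand for lower lipophilicity and higher numbers for higher lipophilicity), compound 1 stands higher than compound 2, by a gap beyond the usual scatter. The two differ in more than one place, so that gap cannot be pinned on any single change.

Compound 3 `CCOC(=O)C1=C(C)NC(=S)NC1c1cn(C(=O)CNc2ccc(Cl)cc2)c2ccccc12` differs from compound 1 in one place only, with 4-chlorophenyl in place of 2-methyl-4-nitrophenyl on an amine nitrogen. Going by the values given here, no measured pair shows a comparable swap, so what follows is a judgement. Starting from compound 1 at 3.34 a modest rise is expected, small beside the gap between the measured pair. The estimated rise is a number 0.36 log units higher from compound 1 to compound 3 (beyond the scatter) in this reading. Compound 3 is expected at 3.7 with an estimated range from 3.2 to 4.3 for this measurement.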

Compound 3, partition coefficient: 3.44
Beside the measured number, compound 3's estimate is 0.26 log units above it, and the stated range covers the measured number.
By their numbers in this assay, from the lowest: compound 2; then compounds 1 and 3 (each within the scatter of the next).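

In this assay, going by these compounds alone, the swap of 2-methyl-4-nitrophenyl for 4-chlorophenyl on the amine nitrogen gives a number 0.10 log units higher from compound 1 to compound 3 (within the scatter), the first step here that changes one place only. The two groups are far from alike: the one that leaves has 10 heavy atoms and 2 hydrogen-bond acceptors, the one that enters has 7 heavy atoms and no hydrogen-bond acceptors, yet this one pair of compounds is not told apart by the read-out. No measurement on hand explains this outcome.

From the compounds shown here alone, whether the same holds for very different groups on this amine nitrogen, such as one bearing a carboxylic acid or a longer chain, remains open. The large gap to compound 2 also still cannot be pinned on any single change.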